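Swapping an isopropyl ester for an acyloxymethyl ester

A few compounds are considered here, and "the series" means these few. Any claim that something is new, unique, unknown or untested is made for them only; others in the source may bear on it.

Measured compounds in a physicochemical assay for metabolic stability, read by LC-MS, in phosphate buffer, with a stated time of 3 h, at pH 7.4, tested at 50 uM; a lower number here means that less of the compound is left, a higher number that more of the compound is left:
Compound 1 `Cc1oc(=O)oc1COC(=O)N1C[C@@H]2C[C@H]1C(=O)Nc1cccc(c1)C(=O)OCc1oc(=O)oc1COC(=O)C1=C(S2)[C@H](C)[C@@H]2[C@@H]([C@@H](C)O)C(=O)N12` gives > 95%.
Compound 2 `CC(C)OC(=O)c1cccc(NC(=O)[C@@H]2C[C@H](SC3=C(C(=O)O)N4C(=O)[C@H]([C@@H](C)O)[C@H]4[C@H]3C)CN2)c1` gives > 95%.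
Compound 3 `CC(C)OC(=O)C1=C(S[C@@H]2CN[C@H](C(=O)Nc3cccc(C(=O)OC(C)C)c3)C2)[C@H](C)[C@@H]2[C@@H]([C@@H](C)O)C(=O)N12` gives > 95%.

None of these three values is a number; each is a limit of the assay, as summed up by the limit of > 95% in this assay, at which 3 of the 3 values shown sit. Compound 2 therefore stands at the limit in this assay, and the two other measured compounds stand at the same limit, so no order among them can be read. For the measured compounds named here, the only step between measured compounds that differ in one place, a step that the two limits leave unreadable from compound 2 to compound 3, has no readable size: both of its ends are limits.

The compound to be measured next is compound 4 `CC(C)C(=O)OCOC(=O)c1cccc(NC(=O)[C@@H]2C[C@H](SC3=C(C(=O)O)N4C(=O)[C@H]([C@@H](C)O)[C@H]4[C@H]3C)CN2)c1`. It differs from compound 2 in one place: ((isopropylcarbonyl)oxy)methyl in place of isopropyl on an oxygen next to a carbonyl group.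

Going by the values given here, no measured step gives a size or a direction that could be carried over to this change. What the measured compounds do show is that every one of them, whatever ester it carries, stays at the limit in this assay. On that basis the expected step from compound 2 to compound 4 is a number at least 2 percentage points lower from compound 2 to compound 4 (that floor lies within the scatter), that is, no change beyond the scatter. For compound 4 the estimated value in this assay is 93%, with a range from 80% to 100%, and a result that is again only a limit is thought likely.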

Compound 4, percent of the compound remaining: > 95%
Compound 4 ended at the assay's limit (the forecaster's own chance of this, stated with the estimate: 65%); middle value at least 2 percentage points from the limit.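

In this assay compound 4 gives > 95% as a limit, not a number. For the compounds shown here, compound 2 also stands at a limit, so no step from it to compound 4 can be read: the limit of > 95% in this assay, at which 4 of the 4 values shown sit. The compounds shown leave open whether compound 1, compound 2, compound 3 and compound 4 differ at all in how much of each remains.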